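Swapping ethyl for cyclopropyl on a fast-cleared compound

A few compounds are considered here, and "the series" means these few. Any claim that something is new, unique, unknown or untested is made for them only; others in the source may bear on it.

compound 1 `CCn1cnc2c(-c3ccc(F)c(OCc4ccccn4)c3)cnnc21` gives 41 mL.min-1.g-1
compound 2 `N#Cc1ccc(Oc2cc(-c3cnnc4c3ncn4C3CC3)ccc2F)nc1` gives 17 mL.min-1.g-1
compound 3 `CCn1cnc2c(-c3ccc(F)c(-c4ccnc(C)c4)c3)cnnc21` gives 157 mL.min-1.g-1

In an ADME assay on microsomes from liver (Homo sapiens) for metabolic stability (a higher number here means faster removal of the compound, a lower number slower removal), compound 3 has the highest of the three numbers at 157 mL.min-1.g-1 and so is removed fastest. Compound 4 `Cc1cc(-c2cc(-c3cnnc4c3ncn4C3CC3)ccc2F)ccn1` has cyclopropyl in place of ethyl on an aromatic nitrogen and is otherwise the same as compound 3. Among the compounds with values here, the only measured step (a 3.8-fold higher number from compound 1 to compound 3 (0.58 log units; beyond the scatter)) changes a different place, so it shows how far one swap can move this number but says nothing direct about this one. Compound 1 with ethyl shows 41 mL.min-1.g-1 and compound 2 with cyclopropyl shows 17 mL.min-1.g-1 but those two also differ elsewhere, so their gap cannot be assigned to this change alone. That gap offers only a weak hint, and a small downward step is expected, possibly no larger than the usual scatter. The estimated step is a 1.8-fold lower number from compound 3 to compound 4 (0.27 log units; within the scatter) and it remains uncertain. Compound 4 is expected near 85 mL.min-1.g-1 within a range of 40 mL.min-1.g-1 to 170 mL.min-1.g-1 in this assay once measured.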

Compound 4, intrinsic clearance in microsomes: 42 mL.min-1.g-1
Compound 4: the middle estimate sits 2.0-fold (0.31 log units) above what was measured; the measured number falls inside the stated range.
By their numbers in this assay, from the lowest: compound 2; then compounds 1 and 4 (each within the scatter of the next); then compound 3.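

In this assay, the swap of ethyl for cyclopropyl on the aromatic nitrogen can now be read alone, with everything else held the same, and it gives a 3.7-fold lower number from compound 3 to compound 4 (0.57 log units; beyond the scatter). So this small group on the five-membered ring is enough to move the number beyond the scatter, at least on the core shared by these compounds. With cyclopropyl fixed, the other place can also be read, where 2-methylpyridin-4-yl in place of (5-cyanopyridin-2-yl)oxy on an aromatic carbon gives a 2.5-fold higher number from compound 2 to compound 4 (0.39 log units; beyond the scatter), and no evidence at hand explains either step.

Going by these compounds, it remains open whether the same swap would lower the number with the (pyridin-2-yl)methoxy group of compound 1. On these data alone, how a cyclobutyl ring, a longer chain such as propyl, or a chain carrying an amine would behave on that nitrogen also remains unknown.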